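The source may hold more compounds than are shown below. What is called first, only, known or untested is meant among the compounds shown, and "the series" means these compounds.

Of the compounds shown here, three that share one core have been tested in a functional assay on HeLa cells (Homo sapiens) for inhibition, read by sulforhodamine B assay; on this read-out lower numbers stand for stronger inhibition and higher numbers for weaker inhibition. Compound 1 `CCCN(CCC)C1=CC(=O)c2nc3n(c2C1=O)[C@H]1OC[C@@H](O)[C@H]1OC3` carries a dipropylamino group on a double-bonded ring carbon, and in this assay compound 1 reaches only the limit > 16000 nM, which is a boundary of the assay and not a number. Compound 2 `COc1ccccc1NC1=CC(=O)c2nc3n(c2C1=O)[C@H]1OC[C@@H](O)[C@H]1OC3`, with a (2-methoxyphenyl)amino group in that place, gives 2950 nM. Compound 3 `O=C1C=C(Nc2ccccc2F)C(=O)c2c1nc1n2[C@H]2OC[C@@H](O)[C@H]2OC1`, with a (2-fluorophenyl)amino group, gives 5120 nM; of the two actual numbers it is the higher, though the step between these two (a 1.7-fold higher number from compound 2 to compound 3 (0.24 log units; within the scatter)) lies within the scatter. Compound 4 `O=C1C=C(N2CCCC2)C(=O)c2c1nc1n2[C@H]2OC[C@@H](O)[C@H]2OC1` is not yet measured and differs from compound 3 in one place: pyrrolidin-1-yl in place of (2-fluorophenyl)amino on a double-bonded ring carbon. The measured steps that bear on this run the opposite way, an at least 5.4-fold lower number from compound 1 to compound 2 (0.73 log units; beyond the scatter) and an at least 3.1-fold lower number from compound 1 to compound 3 (0.49 log units; beyond the scatter), each going from a dialkylamino group to an arylamino group. Pyrrolidin-1-yl is again a dialkylamino group, so a move back toward the limit of > 16000 nM in this assay, at which 1 of the 3 values shown sits, seems likely. The expected step is a 2.9-fold higher number from compound 3 to compound 4 (0.47 log units; beyond the scatter). Compound 4 is therefore estimated at about 15000 nM, probably between 5000 nM and 40000 nM, and may be reported only as a limit.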

Compound 4, half-maximal inhibitory concentration: > 16000 nM
Compound 4 ended at the assay's limit; the forecaster's own chance of this, stated with the estimate: 50%; middle value at least 1.0-fold (0.02 log units) away from the limit.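

Pyrrolidin-1-yl in place of an arylamino group gives an at least 3.1-fold higher number from compound 3 to compound 4 (0.49 log units; beyond the scatter), and an at least 5.4-fold higher number from compound 2 to compound 4 (0.73 log units; beyond the scatter). On this double-bonded ring carbon, then, the weak result is not confined to the open dipropylamino chain of compound 1, since a dialkylamino group closed into a ring also falls away from both arylamino compounds. Compound 4 sits at a limit of the assay and not at a number, as does compound 1, so the step between those two cannot be read: the limit of > 16000 nM in this assay, at which 2 of the 4 values shown sit.

Both readable steps remove the aromatic ring and the hydrogen-bond donor together, so the compounds shown cannot tell which of the two matters. A cyclohexylamino group, which keeps the amine hydrogen without an aromatic ring, and a methyl(phenyl)amino group, which keeps the aromatic ring without that hydrogen, would separate them.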